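Aryl swap on the shared core: compound 2 to compound 3

The source may report more compounds than this note shows. Statements on the series, on what has been measured and on what is new or still open speak of the compounds shown alone.

Among the compounds with values here, compound 2 `COc1ccc(-c2cc(OC)cc(C(=O)Nc3nn[nH]n3)n2)cc1` gives 25% in a functional assay on the whole organism for inhibition, with Rattus norvegicus as the target, at a dose of 1 mg/kg by the oral route (on this read-out lower numbers stand for a weaker effect and higher numbers for a stronger effect at the one dose given), the lowest of the two numbers measured so far; compound 1 `COc1cc(C(=O)Nc2nn[nH]n2)nc(-c2ccccc2OC)c1` gives 41%, and the step of a number 16 percentage points lower from compound 1 to compound 2 (beyond the scatter). Compound 3 `COc1cc(C(=O)Nc2nn[nH]n2)nc(-c2ccc(C)c(C)c2)c1` differs from compound 2 by 3,4-dimethylphenyl in place of 4-methoxyphenyl on an aromatic carbon. Within the data shown here, no measured step bears directly on this change: the one step seen shifted a methoxy group rather than exchanging it for methyls, so its size is only a weak guide. The expected step from compound 2 to compound 3 is therefore small, a number 5 percentage points higher from compound 2 to compound 3 (within the scatter). Compound 3 is estimated at 30%, with a range from 10% to 55%.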

Compound 3, a percentage reported as inhibition, in the whole organism at one dose (the size of the read-out at that dose, not a potency): 21%
Estimate against measurement, compound 3: 9 percentage points above; low and high end bracket the measured number.
By their numbers in this assay, from the lowest: compounds 3 and 2 (each within the scatter of the next); then compound 1.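

In this assay, 3,4-dimethylphenyl in place of 4-methoxyphenyl gives a number 4 percentage points lower from compound 2 to compound 3 (within the scatter), so at this aromatic carbon next to the ring nitrogen, the hydrogen-bond acceptor of 4-methoxyphenyl is not required to hold the read-out at the level of compound 2. The 2-methoxyphenyl group now stands apart from a second aryl group, with a number 20 percentage points lower from compound 1 to compound 3 (beyond the scatter) in the same direction as the earlier step. Nothing available explains either step.

Open, as far as these compounds go, is whether 2-methoxyphenyl is matched by 2-methylphenyl, which would separate the place of the substituent from the methoxy group itself. Also open, from the compounds shown here alone, is how an amine or a carboxylic acid on the phenyl ring would read at this carbon.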